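Swapping an aryl group on a sulfonamide: cytotoxicity expectation

The source may hold more compounds than are shown below. What is called first, only, known or untested is meant among the compounds shown, and "the series" means these compounds.

Measured compounds:
- compound 1, `COc1ccc([C@H]2CC(=O)N(Cc3cccc(C#N)c3)C2)cc1OC1CCCC1`: > 10000 nM
- compound 2, `COc1ccc([C@H]2CC(=O)N(c3cccc(NS(=O)(=O)c4cccc(OC(F)(F)F)c4)c3)C2)cc1OC1CCCC1`: > 10000 nM

Both measured compounds were tested in a functional assay on HEK293 cells (Homo sapiens) for cytotoxicity; a higher number here means that more compound is tolerated, a lower number that less compound is tolerated. Compound 1 gives > 10000 nM, which is a limit of the assay rather than a number. Compound 2 likewise gives > 10000 nM, again a limit and not a number. Compound 2 therefore stands at the ceiling of what was measured, as does the only other compound shown; this is summed up by the limit of > 10000 nM in this assay, at which 2 of the 2 values shown sit. Among the measured compounds shown here, no step between two numbers exists here, so nothing can be said about how large a change in structure shifts the read-out.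

Compound 3, `COc1ccc([C@H]2CC(=O)N(c3cccc(NS(=O)(=O)c4cc(Br)c(Cl)s4)c3)C2)cc1OC1CCCC1`, has not been measured yet. Relative to compound 2 it carries 4-bromo-5-chlorothiophen-2-yl in place of 3-(trifluoromethoxy)phenyl on a sulfonyl sulfur. For the measured compounds named here, with no measured step to lean on, the expectation rests on the fact that both compounds shown sit at the limit. The step from compound 2 to compound 3 is expected to be a number no higher from compound 2 to compound 3 (the limit leaves the size open), that is, none beyond the scatter. Compound 3 is thus expected to give about 10000 nM in this assay, with a range from 4000 nM to 25000 nM.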

Compound 3, half-maximal cytotoxic concentration: > 10000 nM
Compound 3: only a limit was reported; the forecaster's own chance of this, stated with the estimate: 75%; the middle value sits exactly at the limit.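

Among the compounds shown here, compound 2 and compound 3 each give a limit of the assay rather than a number, so no step between them can be read in this assay. All the compounds shown share this result: the limit of > 10000 nM in this assay, at which 3 of the 3 values shown sit.

They leave open whether 4-bromo-5-chlorothiophen-2-yl in place of 3-(trifluoromethoxy)phenyl changes the half-maximal cytotoxic concentration at all.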